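Swapping the aryl group on the hydrazone carbon

The source may hold more compounds than are shown below. What is called first, only, known or untested is meant among the compounds shown, and "the series" means these compounds.

Two compounds share one core and differ only at a carbon with a double bond to nitrogen. Compound 1 `COc1ccccc1-c1nnc(-c2ccc(C(=O)N/N=C/c3ccccn3)cc2)o1` carries pyridin-2-yl there; in an ADME assay on THP-1 cells (Homo sapiens) for cytotoxicity (a higher number here means a weaker inhibitor, a lower number a stronger inhibitor), compound 1 gives 67000 nM. Compound 2 `COc1ccc(O)c(/C=N/NC(=O)c2ccc(-c3nnc(-c4ccccc4OC)o3)cc2)c1` carries 2-hydroxy-5-methoxyphenyl instead, and in this assay compound 2 gives 303000 nM, the highest of the two numbers, with a 4.5-fold higher number from compound 1 to compound 2 (0.66 log units; beyond the scatter). Compound 3 `COc1ccccc1-c1nnc(-c2ccc(C(=O)N/N=C/c3ccc(O)cc3)cc2)o1` is not yet measured; its difference from compound 2 is 4-hydroxyphenyl in place of 2-hydroxy-5-methoxyphenyl on a carbon with a double bond to nitrogen. For the measured compounds named here, no measured step covers this exact exchange. Going by the values given here, the one step that touches the same position, a 4.5-fold higher number from compound 1 to compound 2 (0.66 log units; beyond the scatter), shows that changing the group here can move the number by a modest amount, and compound 3 keeps a hydroxy-bearing phenyl while shedding part of it. Compound 3 is therefore expected to lie between its two neighbours, with an expected step of a 2.0-fold lower number from compound 2 to compound 3 (0.31 log units; beyond the scatter), giving an estimate of 150000 nM in this assay, within a range from 60000 nM to 400000 nM.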

Compound 3, half-maximal inhibitory concentration: 261000 nM
The estimate for compound 3 lay 1.7-fold (0.24 log units) below the measured number; measured number inside the range.
By their numbers in this assay, from the lowest: compound 1; then compounds 3 and 2 (each within the scatter of the next).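

In this assay, the step of a 1.2-fold lower number from compound 2 to compound 3 (0.06 log units; within the scatter) lies within the scatter, so at this carbon with a double bond to nitrogen, 4-hydroxyphenyl and 2-hydroxy-5-methoxyphenyl cannot be told apart. The larger group's extra methoxy and its different hydroxy placement therefore show no measurable effect in this pair. The step of a 3.9-fold higher number from compound 1 to compound 3 (0.59 log units; beyond the scatter) lies beyond the scatter. The step of a 4.5-fold higher number from compound 1 to compound 2 (0.66 log units; beyond the scatter) runs the same way, so among these three compounds, compound 1 with pyridin-2-yl is the one that stands apart.

Still open, from the compounds shown here alone, is whether plain phenyl, pyridin-4-yl or an aminophenyl group would fall with compound 1 or with compounds 2 and 3. Nothing available here accounts for the separate position of compound 1.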